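A few compounds are considered here, and "the series" means these few. Any claim that something is new, unique, unknown or untested is made for them only; others in the source may bear on it.

Measured compounds:
- compound 1 `O=C(c1ccccc1)N1CCC(N(C2CC2)S(=O)(=O)c2cccc(C(F)(F)F)c2)CC1` — "not determined" (no result reported)
- compound 2 `NC(=O)c1ccccc1C(=O)N1CCC(N(C2CC2)S(=O)(=O)c2cccc(C(F)(F)F)c2)CC1` — 17%

For the measured compounds named here, in an assay on cells for inhibition of Voltage-dependent L-type calcium channel subunit alpha-1C (Homo sapiens), read by FLIPR and calcium flux, tested at 3 uM (a lower number here means a weaker effect, a higher number a stronger effect of the compound at the concentration tested), compound 2 gives 17%, the only number available here, since compound 1 has "not determined" (no result reported) in this assay. Compound 3 `CS(=O)(=O)c1ccc(F)cc1C(=O)N1CCC(N(C2CC2)S(=O)(=O)c2cccc(C(F)(F)F)c2)CC1` is not yet measured. It differs from compound 2 in one place: 5-fluoro-2-(methylsulfonyl)phenyl in place of 2-carbamoylphenyl on a carbonyl carbon. Without any measured pair to show what such a change does, the expectation is a step from compound 2 to compound 3 no larger than the usual scatter, with no clear direction. Compound 3 is therefore estimated at 20% in this assay, within a range of 5% to 40%, which means an expected step of a number 3 percentage points higher from compound 2 to compound 3 (within the scatter).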

Compound 3, a percentage reported as inhibition, at one concentration (the size of the read-out at that concentration, not a potency): 34%
Compound 3: middle estimate off by 14 percentage points, on the low side, and the stated range covers the measured number.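

In this assay, replacing 2-carbamoylphenyl with 5-fluoro-2-(methylsulfonyl)phenyl on the carbonyl carbon gives a number 17 percentage points higher from compound 2 to compound 3 (beyond the scatter), the first sign that the read-out responds to a change at this position. The entering group has no hydrogen-bond donor and brings in fluorine and sulfur, but these differences arrive together. Nothing shown here explains the rise.

Which part of the new group accounts for the step remains open. So does the effect of a carboxylic acid or a nitrile at this position.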